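The source may report more compounds than this note shows. Statements on the series, on what has been measured and on what is new or still open speak of the compounds shown alone.

Among the measured compounds shown here, the two compounds measured so far share one core. Compound 1 `O=C(O)Cc1sc(C(c2ccccc2)c2ccc(Cl)cc2)nc1-c1ccc(Cl)cc1` in an in vitro functional assay on HEK285-7 cells for antagonist activity at prostaglandin D2 receptor 2 (Homo sapiens), read by BRET and beta-arrestin recruitment (a lower number here means a smaller maximal response, a higher number a larger maximal response), gives 80%. Compound 2 `O=C(O)Cc1sc(C(c2ccc(F)cc2)c2ccc(F)cc2)nc1-c1cccc(F)c1` in this assay gives 80%, a value level with that of compound 1 within the usual scatter of the measurement. For the measured compounds named here, no step between two measured compounds that differ in a single place has been recorded, so there is no measured precedent on this core for any single exchange of a group.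

Compound 3 `Cc1cc(-c2nc(C(c3ccc(F)cc3)c3ccc(F)cc3)sc2CC(=O)O)ccn1` has not yet been measured. It differs from compound 2 in one place: 2-methylpyridin-4-yl in place of 3-fluorophenyl on an aromatic carbon. Going by the values given here, no measured pair shows what replacing a six-membered aromatic ring of carbon only by a six-membered aromatic ring with one hetero atom does to the maximal response in this assay; the two values in hand show only that compound 1 and compound 2 stand at the same level. The step of a number 2 percentage points lower from compound 2 to compound 3 (within the scatter) is therefore expected to be small, with no clear direction beyond the scatter. Compound 3 is estimated to give 78% in this assay, with a range from 60% to 95%.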

Compound 3, largest response reached (reported as efficacy), in percent of the reference or control that the assay uses: 80%
The estimate for compound 3 lay 2 percentage points below the measured number; the measured number falls inside the stated range.
By their numbers in this assay, from the lowest: compounds 1, 2 and 3 (each within the scatter of the next).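

In this assay, among the compounds shown here, putting 2-methylpyridin-4-yl in place of 3-fluorophenyl gives no change at the digits printed from compound 2 to compound 3 (within the scatter), and this is the first step on the shared core in which only one place differs. It shows that, on this aromatic carbon next to the ring nitrogen and next to the ring atom that bears a carboxymethyl group, a six-membered aromatic ring of carbon only can give way to one with a hetero atom while the maximal response stays level within the scatter. Nothing measured here offers an explanation for the two groups standing level.

This single exchange removes the fluorine and brings in both the ring nitrogen and the methyl group, so the compounds shown do not tell these parts apart, and a pyridin-4-yl without the methyl group or a plain phenyl would be needed to separate them. They also leave open whether the level holds for groups of another kind at this position, such as a ring carrying an amine or a longer chain.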